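This account rests on a few compounds, and the source may have more. Where it says the series, first, only, none or still open, it means among the compounds named here.

Working notes on four compounds built on one shared core, differing at two places on it.

In a functional assay on MCF7 cells (Homo sapiens) for antiproliferative activity, read by MTT assay, with a stated time of 48 h (a lower number here means a stronger inhibitor, a higher number a weaker inhibitor), compound 2 `CS(=O)(=O)c1ccc(Nc2nccc(Nc3nc4ccc(Cl)cc4s3)n2)cc1` gives only a limit, > 50000 nM, and no number. Compound 1 `Cc1cnc(Nc2ccc(S(C)(=O)=O)cc2)nc1Nc1nc2ccc(Cl)cc2s1` differs from compound 2 by methyl in place of hydrogen on an aromatic carbon, and in this assay compound 1 gives 4320 nM. The step is an at least 11-fold lower number from compound 2 to compound 1 (1.06 log units; beyond the scatter); its size is known only from one side because of the limit of > 50000 nM in this assay, at which 1 of the 3 values shown sits.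

Compound 3 `NS(=O)(=O)c1ccc(Nc2nccc(Nc3nc4ccc(F)cc4s3)n2)cc1` has a core that differs from that of compound 2 in more than one place; the difference between the two cores is not broken down here. In this assay compound 3 gives 10900 nM, the highest number among the measured compounds and a larger number than compound 1 by a step beyond the scatter.

Compound 4 `Cc1cnc(Nc2ccc(S(N)(=O)=O)cc2)nc1Nc1nc2ccc(F)cc2s1` is not yet measured. It differs from compound 3 by methyl in place of hydrogen on an aromatic carbon, the same change as from compound 2 to compound 1, with the place described in the same words. For compound 4 in this assay the expected step is a 7.3-fold lower number from compound 3 to compound 4 (0.86 log units; beyond the scatter), resting on an at least 11-fold lower number from compound 2 to compound 1 (1.06 log units; beyond the scatter) in the same place, kept on the cautious side since that earlier step starts from a limit and the pair of cores carrying the change is not the same. Compound 4 is therefore estimated at 1500 nM. The expected range for compound 4 runs from 500 nM to 5000 nM.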

Compound 4, half-maximal inhibitory concentration: > 50000 nM
Compound 4 gave a limit, no number (the forecaster's own chance of this, stated with the estimate: 2%); at least 33-fold (1.52 log units) between middle value and limit.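

The same methyl in place of hydrogen on an aromatic carbon gives an at least 4.5-fold higher number from compound 3 to compound 4 (0.66 log units; beyond the scatter) in this assay, so on these two cores the change does not carry over in direction, and the gap between the two steps is beyond the scatter: the same change on two cores in this assay, an at least 11-fold lower number (1.06 log units; beyond the scatter) from compound 2 to compound 1 and an at least 4.5-fold higher number (0.66 log units; beyond the scatter) from compound 3 to compound 4, at least 53-fold (1.72 log units) apart, beyond the scatter of two such steps
Each of the two steps has a limit at one end, and their true sizes stay unknown because of that: the limit of > 50000 nM in this assay, at which 2 of the 4 values shown sit.
What this does not show is which difference between the two cores decides the direction: they differ in more than one place, and two pairs say nothing about any core outside them.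

As far as these compounds go, it stays open whether an ethyl group or an amine on the same aromatic carbon would follow the step to compound 1 or the step to compound 4. Also open, from the compounds shown here alone, is how the methyl change behaves on a core that differs from that of compound 2 or compound 3 in one place only, the kind of comparison that could tie the reversal to a single group.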